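Compound 1 at the assay limit: a fluorine swap

A few compounds are considered here, and "the series" means these few. Any claim that something is new, unique, unknown or untested is made for them only; others in the source may bear on it.

Measured in a functional assay on MCF7 cells (Homo sapiens) for antiproliferative activity, read by MTT assay, with a stated time of 72 h; on this read-out higher numbers stand for weaker inhibition and lower numbers for stronger inhibition:
Compound 1 `COc1ccc(/C=C2\S/C(=N\c3ccc(C)c(Cl)c3)N(C)C2=O)cc1`: > 100000 nM (a limit of the assay, not a number)
Compound 2 `FC(F)(F)c1cc(/N=C2/NC/C(=C/c3ccccc3)S2)cc(C(F)(F)F)c1`: 13500 nM

Compound 1 gives > 100000 nM, and this is a limit of the assay rather than a true number. So its real position on the scale is not known. Compound 3 `COc1ccc(/C=C2\S/C(=N\c3ccc(F)cc3)N(C)C2=O)cc1` has not been measured yet. It keeps the core of compound 1 but carries 4-fluorophenyl in place of 3-chloro-4-methylphenyl on a double-bonded nitrogen. Among the compounds with values here, no measured pair shows what such a swap does in this assay, so any expectation here is loose. Only a modest shift towards stronger inhibition is expected, and the result may again be only a limit. The expected change is an at least 1.6-fold lower number from compound 1 to compound 3 (0.22 log units; that floor lies within the scatter). For compound 3 the estimated value is 60000 nM, with an expected range of 20000 nM to 150000 nM.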

Compound 3, half-maximal inhibitory concentration: 66500 nM
Estimate against measurement, compound 3: 1.1-fold (0.04 log units) below; measured number inside the range.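

In this assay, compound 3 gives 66500 nM, a real number on the shared core, so a change at this place on the double-bonded nitrogen can bring the core into the range the assay can read. Compound 1 gives > 100000 nM, which is a limit of the assay and not a number. Putting 4-fluorophenyl in place of 3-chloro-4-methylphenyl therefore gives an at least 1.5-fold lower number from compound 1 to compound 3 (0.17 log units; that floor lies within the scatter), so only a floor is known and the true size of the step stays open: the limit of > 100000 nM in this assay, at which 1 of the 3 values shown sits.

This single swap changes the ring in more than one way, so it cannot separate what the chlorine, the methyl and the fluorine each contribute. The compounds shown also leave open what a 4-aminophenyl or a 4-carboxyphenyl group would do on the same nitrogen.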